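Replacing bromo in compound 1: expectation for compound 4

This account rests on a few compounds, and the source may have more. Where it says the series, first, only, none or still open, it means among the compounds named here.

Values measured so far in a functional assay on PC-3 cells (Homo sapiens) for inhibition, read by MTT assay, with a stated time of 48 h (on this read-out lower numbers stand for stronger inhibition and higher numbers for weaker inhibition), for the series:

- compound 1 `COc1ccc(-c2coc3cc(OCCCBr)ccc3c2=O)cc1` gives 62600 nM
- compound 2 `COc1ccc(-c2coc3cc(OCCCSC(=S)N4CCN(C)CC4)ccc3c2=O)cc1` gives 2210 nM
- compound 3 `CCN1CCN(C(=S)SCCCOc2ccc3c(=O)c(-c4ccc(OC)cc4)coc3c2)CC1` gives 7080 nM
- compound 4 `COc1ccc(-c2coc3cc(OCCCSC(=S)N4CCCC4)ccc3c2=O)cc1` has no value yet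

Compound 1 carries the highest number of the measured set, at 62600 nM in these notes. The change in compound 4 relative to compound 1 is a group of 8 heavy atoms (5 carbon, 1 nitrogen, 2 sulfur; one five-membered non-aromatic ring with 1 hetero atom) in place of one bromine atom, on a saturated chain carbon, three bonds along the chain from an oxygen on an aromatic ring and the rest of the structure stays the same.

Two measured steps replace the same bromine atom at the same place. One is a 28-fold lower number from compound 1 to compound 2 (1.45 log units; beyond the scatter) and the other is an 8.8-fold lower number from compound 1 to compound 3 (0.95 log units; beyond the scatter) and both lead to lower numbers. The entering groups in these two steps differ by a single methyl in place of hydrogen, and that difference alone gives a 3.2-fold higher number from compound 2 to compound 3 (0.51 log units; beyond the scatter) in this series. Going by the values given here, no measured compound carries the five-membered non-aromatic ring of compound 4, so the expectation rests on these two steps alone.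

The estimated step is a 14-fold lower number from compound 1 to compound 4 (1.14 log units; beyond the scatter) in this assay and is expected to lead to a lower number, with a size inside the span of the two measured replacements. For compound 4 the expected value is 4500 nM with an estimated range from 1500 nM to 14000 nM on this read-out.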

Compound 4, half-maximal inhibitory concentration: 19400 nM
Compound 4: middle estimate off by 4.3-fold (0.63 log units), on the low side; the measured number lies above the stated range.
By their numbers in this assay, from the lowest: compound 2; then compound 3; then compound 4; then compound 1.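

In this assay a third group can take the place of the bromine atom on the saturated chain carbon and still give a lower number (  a 3.2-fold lower number from compound 1 to compound 4 (0.51 log units; beyond the scatter)), so all three replacements shown point the same way, although the one in compound 4 gives the smallest step of them. The earlier compounds shown here varied only a methyl in place of hydrogen at the far end of the six-membered ring, whereas this result shows that changing the ring itself on the thiocarbonyl carbon also matters: pyrrolidin-1-yl gives a higher number than 4-ethylpiperazin-1-yl (  a 2.7-fold higher number from compound 3 to compound 4 (0.44 log units; beyond the scatter)) and than 4-methylpiperazin-1-yl (  an 8.8-fold higher number from compound 2 to compound 4 (0.94 log units; beyond the scatter)). No supporting information on hand explains this order.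

Pyrrolidin-1-yl differs from both piperazinyl groups in ring size and in its count of hetero atoms as well as in lacking their alkyl group, so the compounds shown cannot say which of these differences carries the step. From the compounds shown here alone, a piperidin-1-yl group on the thiocarbonyl carbon would keep the six-membered ring with 1 hetero atom, and an unsubstituted piperazin-1-yl group would remove the alkyl group, so the effect of each remains open.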